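One ring exchanged on a sulfur

The compounds below may be only part of what the source reports. "The series", "measured", "known", "first", "only" and "open" are said of these compounds alone.

In a functional assay on NCI-H1975 cells (Homo sapiens) for inhibition, read by MTT assay, with a stated time of 72 h (a higher number here means a weaker inhibitor, a lower number a stronger inhibitor), compound 1 `FC(F)(F)c1ccc(CSc2nc(N3CCN(c4ccccc4)CC3)cc(C(F)(F)F)n2)cc1` gives > 50000 nM as its result, which is a limit and not a number. Compound 2 `CC(C)(C)OC(=O)N1CCN(c2cc(C(F)(F)F)nc(SCc3ccc(C(F)(F)F)cc3)n2)CC1` likewise returns only a limit, > 50000 nM in its case. Among the measured compounds shown here, compound 3 `Cc1csc(Sc2cc(C(F)(F)F)nc(SCc3ccc(C(F)(F)F)cc3)n2)n1` gives 5840 nM and is the only compound with a number. Everything else shown is the limit of > 50000 nM in this assay, at which 2 of the 3 values shown sit, and so offers no scale around it.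

Compound 4 `Cc1nnc(Sc2cc(C(F)(F)F)nc(SCc3ccc(C(F)(F)F)cc3)n2)s1` carries 5-methyl-1,3,4-thiadiazol-2-yl in place of 4-methyl-1,3-thiazol-2-yl on a sulfur and is otherwise the same as compound 3. For the measured compounds named here, no measured step touches this place. Going by the values given here, the one step available is a step that the two limits leave unreadable from compound 1 to compound 2 and it lends no size to carry over. The expectation therefore starts from compound 3 at 5840 nM and assumes no movement beyond the scatter. The estimate is a 1.2-fold higher number from compound 3 to compound 4 (0.08 log units; within the scatter) as the expected change. For compound 4 the expected value is 7000 nM with an estimated range of 2000 nM to 30000 nM in this estimate.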

Compound 4, half-maximal inhibitory concentration: 3060 nM
The estimate for compound 4 lay 2.3-fold (0.36 log units) above the measured number; low and high end bracket the measured number.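

On a sulfur whose other neighbour is an aromatic carbon, 5-methyl-1,3,4-thiadiazol-2-yl in place of 4-methyl-1,3-thiazol-2-yl gives a 1.9-fold lower number from compound 3 to compound 4 (0.28 log units; within the scatter) in this assay. Among the compounds shown here, this is the first step that can be read, and it shows that exchanging one ring carbon for a nitrogen at this place, which adds a hydrogen-bond acceptor by count, leaves the result within the scatter. The step from compound 1 to compound 2 still cannot be read, and the other values remain a limit and not a number: the limit of > 50000 nM in this assay, at which 2 of the 4 values shown sit.

As far as these compounds go, what happens on this sulfur with a group other than a methyl-bearing five-membered ring, such as an open chain ending in a carboxylic acid, stays open. Both rings carry a methyl, so whether an amine or a plain hydrogen could stand in its place is also unanswered.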